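The source may hold more compounds than are shown below. What is called first, only, known or untested is meant among the compounds shown, and "the series" means these compounds.

Of the compounds shown here, two have been measured in an assay on membranes from CHO cells for displacement of a labelled ligand from adenosine receptor A1 (Homo sapiens), read by scintillation counting, with a stated time of 60 min, tested at 1 uM; a higher number here means more inhibition at the concentration tested (going by the name of the read-out), a lower number less inhibition. Compound 1, with the structure `CCCC(=O)C1=C(C)NC(=O)NC1c1ccsc1`, carries a butanoyl group on the shared core together with a thiophen-3-yl ring; in this assay compound 1 gives 6%. Compound 2, with the structure `CCN(CC)C(=O)C1=C(C)NC(=O)NC1c1cccs1`, carries a diethylamide instead and a thiophen-2-yl ring; in this assay compound 2 gives 13%. The two readings sit within the usual scatter of each other, so neither number can be called higher or lower than the other on these readings.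

Compound 3, with the structure `CCN(CC)C(=O)C1=C(C)NC(=O)NC1c1ccsc1`, has not been measured yet. It is compound 2 with one change: thiophen-3-yl in place of thiophen-2-yl on a saturated ring carbon. Going by the values given here, both measured values are low, and the only comparison available mixes two changes at once, so no step beyond the scatter is expected from this swap; the step from compound 2 to compound 3 is estimated at a number 3 percentage points lower from compound 2 to compound 3 (within the scatter). Compound 3 is therefore expected to give about 10% in this assay, plausibly between 0% and 25%.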

Compound 3, a percentage reported as inhibition, at one concentration (the size of the read-out at that concentration, not a potency): 11%
Compound 3: the middle estimate sits 1 percentage points below what was measured, and the stated range covers the measured number.
By their numbers in this assay, from the lowest: compounds 1, 3 and 2 (each within the scatter of the next).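

Swapping thiophen-2-yl for thiophen-3-yl on a saturated ring carbon can now be read on its own, with the rest of the molecule unchanged: the step is a number 2 percentage points lower from compound 2 to compound 3 (within the scatter) in this assay and cannot be told apart from no difference at all. Compound 3 also isolates the second difference, diethylamino in place of propyl on a carbonyl carbon, and this step, a number 5 percentage points higher from compound 1 to compound 3 (within the scatter) and likewise within the scatter, shows no clear effect of that swap in this series. No outside data bear on these readings.

The compounds shown leave open whether a longer chain, a piperidine amide or a carboxylic acid at the carbonyl carbon would give a reading beyond the scatter. They also leave open whether a phenyl ring in place of the thiophene on the saturated ring carbon would do so.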